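From an aryl sulfonamide to a methyl sulfonamide

The compounds below may be only part of what the source reports. "The series", "measured", "known", "first", "only" and "open" are said of these compounds alone.

Measured so far:
compound 1 `O=C(O)CCC/C=C\C[C@H]1[C@@H]2CCC(C2)[C@@H]1NS(=O)(=O)c1cccc2ccccc12`: 1100 nM
compound 2 `O=C(O)CCC/C=C\C[C@H]1[C@@H]2CCC(C2)[C@@H]1NS(=O)(=O)c1ccc([N+](=O)[O-])cc1`: 1400 nM
compound 3 `O=C(O)CCC/C=C\C[C@H]1[C@@H]2CCC(C2)[C@@H]1NS(=O)(=O)c1ccc(O)cc1`: 500 nM

All three compounds share one core and differ only in the group carried on the sulfonyl sulfur. In a functional assay (plasma) for inhibition, with Oryctolagus cuniculus as the target (on this read-out higher numbers stand for weaker inhibition and lower numbers for stronger inhibition), compound 1 gives 1100 nM, compound 2 gives 1400 nM and compound 3 gives 500 nM. Compound 3 has the lowest number of the three: a 2.2-fold lower number from compound 1 to compound 3 (0.34 log units; beyond the scatter) and a 2.8-fold lower number from compound 2 to compound 3 (0.45 log units; beyond the scatter), both modest, whereas a 1.3-fold higher number from compound 1 to compound 2 (0.10 log units; within the scatter).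

Compound 4 `CS(=O)(=O)N[C@H]1C2CC[C@H](C2)[C@@H]1C/C=C\CCCC(=O)O` has not yet been measured. It differs from compound 3 in one place: methyl in place of 4-hydroxyphenyl on a sulfonyl sulfur. Within the data shown here, no measured step replaces the aromatic ring with a methyl, so none bears on this change directly; the steps among compounds 1, 2 and 3 only show that exchanging one aromatic group for another moves this assay by small to modest amounts. With the whole ring removed, a shift in either direction is possible, and the uncertainty is wide. Compound 4 is expected to give about 1500 nM, estimated between 400 nM and 6000 nM. This estimate means an expected 3.0-fold higher number from compound 3 to compound 4 (0.48 log units; beyond the scatter).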

Compound 4, half-maximal inhibitory concentration: 640000 nM
For compound 4 the middle estimate is 430-fold (2.63 log units) below the measured one; the measured number lies above the stated range.
By their numbers in this assay, from the lowest: compound 3; then compounds 1 and 2 (each within the scatter of the next); then compound 4.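

In this assay, exchanging one aromatic group for another on the sulfonyl sulfur moved the number only slightly or modestly, but methyl in place of the aromatic group changes it far more. The three steps are a 1300-fold higher number from compound 3 to compound 4 (3.11 log units; beyond the scatter), a 460-fold higher number from compound 2 to compound 4 (2.66 log units; beyond the scatter) and a 580-fold higher number from compound 1 to compound 4 (2.76 log units; beyond the scatter), all large and all pointing to much weaker inhibition. This position is therefore tolerant of quite different aromatic groups, yet all three of them give far stronger inhibition than methyl does, and no measurement shown here explains why.

On these data alone, whether the aromatic ring itself matters, or simply a group larger than methyl, stays open. A cyclohexyl ring or a longer alkyl chain on the sulfonyl sulfur would help to separate these two possibilities.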